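A few compounds are considered here, and "the series" means these few. Any claim that something is new, unique, unknown or untested is made for them only; others in the source may bear on it.

Compound 1 `COc1cc(-c2cc(/C=C/C(=O)c3ccc(N)cc3)[nH]n2)cc(OC)c1OC`: -99%. Compound 2 `COc1ccc(C(=O)/C=C/c2cc(-c3cc(OC)c(OC)c(OC)c3)n[nH]2)cc1OC`: -96%. Compound 3 `COc1ccc(C(=O)/C=C/c2cc(-c3cc(OC)c(OC)c(OC)c3)n[nH]2)cc1`: -92%.

All three were tested in a functional assay on SF-539 cells (Homo sapiens) for cytotoxicity, read by sulforhodamine B assay, with a stated time of 48 h, tested at 100 uM; on this read-out lower numbers stand for a stronger effect and higher numbers for a weaker effect at the one concentration tested. Compound 2 and compound 3 differ by hydrogen in place of methoxy on an aromatic carbon, and on this read-out that change gave a number 4 percentage points higher from compound 2 to compound 3 (within the scatter). Compound 1 and compound 2 share no counted small difference; their cores differ by 4-aminophenyl in place of 3,4-dimethoxyphenyl on a carbonyl carbon, and their read-outs differ by a number 3 percentage points higher from compound 1 to compound 2 (within the scatter). Compound 1 and compound 3 differ by a number 7 percentage points higher from compound 1 to compound 3 (within the scatter). None of these steps leaves the scatter of repeated measurements, so no order among the three compounds can be claimed.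

Compound 4 `COc1ccc(-c2cc(/C=C/C(=O)c3ccc(N)cc3)[nH]n2)cc1OC` has not yet been measured. It differs from compound 1 by hydrogen in place of methoxy on an aromatic carbon. This is the same kind of change as that from compound 2 to compound 3, though not the same: around the place in compound 4 there is also a methoxy group (2 heavy atoms) meta, which the earlier place does not have. From compound 1 to compound 4 a step of a number 4 percentage points higher from compound 1 to compound 4 (within the scatter) is expected, beside the earlier one, because a number 4 percentage points higher from compound 2 to compound 3 (within the scatter) stayed within the scatter. For compound 4 in this assay the estimated value is -95%, expected to lie between -100% and -84%.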

Compound 4, a percentage reported as activity, at one concentration (the size of the read-out at that concentration, not a potency): -92%
For compound 4 the middle estimate is 3 percentage points below the measured one; the measured number falls inside the stated range.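

In this assay, hydrogen in place of methoxy on an aromatic carbon gave a number 7 percentage points higher from compound 1 to compound 4 (within the scatter). Set beside the earlier case of this change, the new step does not differ from it: the same change on two cores in this assay, a number 4 percentage points higher (within the scatter) from compound 2 to compound 3 and a number 7 percentage points higher (within the scatter) from compound 1 to compound 4, 3 percentage points apart, within the scatter of two such steps On these two cores the change therefore carried over without a difference that can be told apart from the scatter, but neither step leaves the scatter, so this does not show that the methoxy group matters to the read-out on either core, nor how the change would behave on any other core.

The compounds shown leave open what a chlorine atom, a hydroxyl group or a longer alkoxy chain would do at this place on the aromatic ring, since only methoxy and hydrogen appear there. With the read-out taken at one concentration, they also leave open whether the methoxy change would separate the compounds at lower concentrations.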